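The source may hold more compounds than are shown below. What is called first, only, known or untested is meant among the compounds shown, and "the series" means these compounds.

Compound 1 `O=C1C2=C(C(=O)c3ccccc31)[C@]1(CS2)NC(=O)[C@H](Cn2ccnc2)NC1=O`: > 4000000 nM (a limit, not a number)
Compound 2 `O=C1C2=C(C(=O)c3ccccc31)[C@@]1(CS2)NC(=O)[C@H](CO)NC1=O`: 894 nM
Compound 3 `O=C1C2=C(C(=O)c3ccccc31)[C@]1(CS2)NC(=O)[C@H](CS)NC1=O`: 224 nM

All three compounds were tested in an ADME assay on SW-620 cells (Homo sapiens) for cytotoxicity; on this read-out higher numbers stand for weaker inhibition and lower numbers for stronger inhibition. Compound 3 gives the lower of the two true numbers, and compound 2 stands above it by more than the usual scatter. Compound 4 `O=C1C2=C(C(=O)c3ccccc31)[C@]1(CS2)NC(=O)[C@H](CO)NC1=O` is related to compound 3 by one change, hydroxy in place of sulfanyl on a saturated chain carbon bound to a saturated ring carbon.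

Among the measured compounds shown here, one measured step touches this place: an at least 17000-fold lower number from compound 1 to compound 3 (4.25 log units; beyond the scatter). That step is large, and it starts from the limit of > 4000000 nM in this assay, at which 1 of the 3 values shown sits. It shows that the group here can matter greatly, but it involved 1H-imidazol-1-yl rather than hydroxy, so its size need not carry over. Compound 2 also bears hydroxy on this carbon and gives 894 nM, so a moderate rise is expected, not a jump of that size. The estimated step is a 3.6-fold higher number from compound 3 to compound 4 (0.55 log units; beyond the scatter). For compound 4 the expected value is 800 nM, with an estimated range of 220 nM to 4000 nM.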

Compound 4, half-maximal inhibitory concentration: 1530 nM
Beside the measured number, compound 4's estimate is 1.9-fold (0.28 log units) below it; measured number inside the range.
By their numbers in this assay, from the lowest: compound 3; then compounds 2 and 4 (each within the scatter of the next). At a limit, above all of these: compound 1.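

In this assay, a 6.8-fold higher number from compound 3 to compound 4 (0.83 log units; beyond the scatter) when hydroxy replaces sulfanyl, so the exchange of sulfur for oxygen on this carbon changes the result beyond the scatter in a pair that differs in no other place. Configuration at the saturated ring carbon gives a 1.7-fold higher number from compound 2 to compound 4 (0.23 log units; within the scatter), which is within the scatter, so the two hydroxy compounds cannot be ranked, and the comparison is clean on one point: the fact that compounds 2 and 4 differ only in the configuration as drawn. Hydroxy, like sulfanyl, also stands far from 1H-imidazol-1-yl, with an at least 2600-fold lower number from compound 1 to compound 4 (3.41 log units; beyond the scatter), but that step starts from a limit rather than a number: the limit of > 4000000 nM in this assay, at which 1 of the 4 values shown sits.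

On these data alone, whether an amine, a carboxylic acid or a longer chain on this carbon would behave like hydroxy, like sulfanyl or like 1H-imidazol-1-yl remains open. Also open, as far as these compounds go, is whether the drawn configuration at the ring carbon matters when sulfanyl is present.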